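This account rests on a few compounds, and the source may have more. Where it says the series, first, only, none or still open, it means among the compounds named here.

Compound 1, `Nc1cc(N)c2nc(-c3ccccc3)c(Oc3ccc(Cl)c(Cl)c3)nc2c1`: 70800 nM in a functional assay on NCI-H460 cells (Homo sapiens) for inhibition, read by sulforhodamine B assay, with a stated time of 48 h; a higher number here means a weaker inhibitor of growth, a lower number a stronger inhibitor of growth.
Compound 2, `CCOC(=O)[C@H](CCC(=O)O)NC(=O)c1ccc(CNc2nc3cc(N)cc(N)c3nc2-c2ccccc2)cc1`: < 100000 nM, a limit of this assay and not a number.
Compound 3, `Nc1cc(N)c2nc(-c3ccccc3)c(NCc3ccc(Cl)c(Cl)c3)nc2c1`: 46800 nM.

Compound 3 has the lowest number of the two numbers given, and compound 1 stands within the scatter of it, so no order between the two can be read. For compound 2 only the limit is known (the limit of < 100000 nM in this assay, at which 1 of the 3 values shown sits).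

Compound 4, `COc1ccc(CNc2nc3cc(N)cc(N)c3nc2-c2ccccc2)cc1OC`, has not yet been measured. It differs from compound 3 by 3,4-dimethoxyphenyl in place of 3,4-dichlorophenyl on a saturated chain carbon bound to a nitrogen on an aromatic ring. Going by the values given here, no measured pair shows the effect of such a change on this scaffold, so only a modest step is expected, if any beyond the scatter, and its direction is open. Compound 4 is therefore estimated at 60000 nM, with a likely range from 25000 nM to 150000 nM, which is the expected step of a 1.3-fold higher number from compound 3 to compound 4 (0.11 log units; within the scatter).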

Compound 4, concentration for total growth inhibition: 91200 nM
Beside the measured number, compound 4's estimate is 1.5-fold (0.18 log units) below it; low and high end bracket the measured number.
By their numbers in this assay, from the lowest: compounds 3, 1 and 4 (each within the scatter of the next).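

In this assay, going by these compounds alone, the 3,4-dimethoxyphenyl and 3,4-dichlorophenyl groups on a saturated chain carbon bound to a nitrogen on an aromatic ring give the first step that can be read on this scaffold: a 1.9-fold higher number from compound 3 to compound 4 (0.29 log units; within the scatter). The two groups therefore cannot be told apart at this position, even though only the 3,4-dimethoxyphenyl group brings hydrogen-bond acceptors. No measurement shown here bears on the reason for this result. On these data alone, whether an amine, a carboxylic acid or a longer chain at this position would give a step beyond the scatter remains open.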